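The source may report more compounds than this note shows. Statements on the series, on what has been measured and on what is new or still open speak of the compounds shown alone.

Measured compounds:
compound 1 `O=C(Nc1ccc(S(=O)(=O)NCc2ccccc2)cc1)c1ccc(Cl)cc1Cl` — "not determined" (no result reported) in a functional assay on HEK293 cells for agonist activity at probable G-protein coupled receptor 27 (Homo sapiens), read by a luciferase reporter and beta-arrestin recruitment, with a stated time of 10 min; on this read-out higher numbers stand for larger maximal responses and lower numbers for smaller maximal responses
compound 2 `O=C(Nc1ccc(S(=O)(=O)Nc2ccccc2)cc1)c1ccc(Cl)cc1Cl` — 100%
compound 3 `Cc1ccc(NS(=O)(=O)c2ccc(NC(=O)c3ccc(Cl)cc3Cl)cc2)cc1` — "not determined" (no result reported) in this assay

Compound 3 therefore stands without a number in this assay; of the three compounds measured, only compound 2 has a reported maximal response, and it reaches the level of the reference. Compound 4 `O=C(Nc1ccc(S(=O)(=O)Nc2ccccc2Cl)cc1)c1ccc(Cl)cc1Cl` is the next compound to be tested in this assay. It differs from compound 3 by 2-chlorophenyl in place of 4-methylphenyl on a sulfonamide nitrogen. Within the data shown here, no step between two measured compounds is known, so the size of the change cannot be read from the data. Given that compound 2, which carries a plain phenyl on the same sulfonamide nitrogen, gives 100%, the expectation for compound 4 is a response near that of compound 2, perhaps somewhat lower. Compound 4 is estimated to give 85%, with a range from 40% to 120%.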

Compound 4, largest response reached (Emax), in percent of the reference or control that the assay uses: 53%
For compound 4 the middle estimate is 32 percentage points above the measured one, within the range that was stated.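

With 2-chlorophenyl on the sulfonamide nitrogen, this assay records a number 47 percentage points lower from compound 2 to compound 4 (beyond the scatter) for chloro in place of hydrogen on an aromatic carbon. This position, previously represented by a number only through the plain phenyl of compound 2, therefore responds to this single change, although compound 4 retains a measurable maximal response. Nothing available accounts for the step. From the compounds shown here alone, whether an amine or a carboxylic acid on that phenyl would change the response remains open. The 4-methylphenyl of compound 3 adds nothing here, since compound 3 has no reported number.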